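A thioamide-to-nitrile swap on a fused two-ring core

This account rests on a few compounds, and the source may have more. Where it says the series, first, only, none or still open, it means among the compounds named here.

In a functional assay on KB cells (Homo sapiens) for cytotoxicity (a higher number here means a weaker inhibitor, a lower number a stronger inhibitor), compound 3 `COc1ccc(Cn2cc(C(=N)S)c3c(N)ncnc32)cc1` gives 28000 nM, the highest of the two numbers in hand. Its nearest neighbour is compound 1 `CC(C)(C)c1ccc(Cn2cc(C#N)c3c(N)ncnc32)cc1`, which in this assay gives 3000 nM. Compound 2 `Cc1ccc(Cn2cc(C#N)c3c(N)ncnc32)cc1` is reported only as a limit of the assay, > 100000 nM, which is the limit of > 100000 nM in this assay, at which 1 of the 3 values shown sits. Among the measured compounds shown here, the one step between measured compounds, an at least 33-fold higher number from compound 1 to compound 2 (1.52 log units; beyond the scatter), concerns a different pair of groups at a different aromatic carbon of the shared core, so it does not bear on the change considered here.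

Compound 4 `COc1ccc(Cn2cc(C#N)c3c(N)ncnc32)cc1` differs from compound 3 by a group of 2 heavy atoms (1 carbon, 1 nitrogen; no ring) in place of a group of 3 heavy atoms (1 carbon, 1 nitrogen, 1 sulfur; no ring), on an aromatic carbon. For the measured compounds named here, no measured pair changes a group at that place, and the measured step gives no guide to direction or size. The cyano compounds 1 and 2 span numbers far apart from one another, so the estimate carries wide uncertainty. For compound 4 a step of about a 1.1-fold higher number from compound 3 to compound 4 (0.03 log units; within the scatter) is expected, no larger than the usual scatter. Compound 4 is therefore estimated at 30000 nM, expected to fall between 6000 nM and 150000 nM.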

Compound 4, half-maximal inhibitory concentration: > 100000 nM
Compound 4: only a limit was reported; the forecaster's own chance of this, stated with the estimate: 30%; middle value at least 3.3-fold (0.52 log units) from the limit.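

In this assay, among the compounds shown here, cyano in place of the group of 3 heavy atoms on this aromatic carbon gives an at least 3.5-fold higher number from compound 3 to compound 4 (0.55 log units; beyond the scatter), the first sign that a change at this place moves the number, and that it moves it upward. With cyano held in place, methoxy in place of tert-butyl gives an at least 33-fold higher number from compound 1 to compound 4 (1.52 log units; beyond the scatter), so among the three cyano compounds only compound 1 gives a readable number. The step between compound 2 and compound 4 cannot be read because both are reported only as limits: the limit of > 100000 nM in this assay, at which 2 of the 4 values shown sit.

From the compounds shown here alone, the full size of the cyano effect stays open, since compound 4 is a limit. Also open, going by these compounds, are how a carboxylic acid or an amide would read at this aromatic carbon, and whether the group of 3 heavy atoms would give a lower number than cyano with tert-butyl in place of methoxy.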